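The source may hold more compounds than are shown below. What is called first, only, known or untested is meant among the compounds shown, and "the series" means these compounds.

Within the data shown here, compound 2 `COc1cc(C[C@@H](C)[C@@H](C)Cc2ccc(OC(=O)c3ccc(Br)cc3)c(OC)c2)ccc1O` stands at the higher of the two numbers so far known in an ADME assay on Vero cells (Chlorocebus sabaeus) for cytotoxicity, read by trypan blue exclusion, with a stated time of 24 h (a lower number here means a stronger inhibitor, a higher number a weaker inhibitor), where compound 2 gives 112 ug/mL. Its nearest neighbour, compound 1 `COc1cc(C[C@@H](C)[C@@H](C)Cc2ccc(OC(=O)c3cccnc3)c(OC)c2)ccc1O`, gives 71.4 ug/mL in this assay, and the step of a 1.6-fold higher number from compound 1 to compound 2 (0.20 log units; within the scatter) lies within the scatter. Compound 3 `COc1cc(C[C@@H](C)[C@@H](C)Cc2ccc(OC(C)=O)c(OC)c2)ccc1O` differs from compound 2 in one place: methyl in place of 4-bromophenyl on a carbonyl carbon. Among the measured compounds shown here, only one measured step bears on this change, the swap of pyridin-3-yl for 4-bromophenyl on the carbonyl carbon, a 1.6-fold higher number from compound 1 to compound 2 (0.20 log units; within the scatter), and it stayed within the scatter. For the measured compounds named here, the present change removes the ring altogether, and no measured pair shows what such a loss does here, so no direction beyond the scatter can be read from the data. Compound 3 is therefore expected to give about 100 ug/mL in this assay, with a range from 50 ug/mL to 200 ug/mL, which would amount to an expected step of a 1.1-fold lower number from compound 2 to compound 3 (0.05 log units; within the scatter).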

Compound 3, half-maximal inhibitory concentration: 112 ug/mL
For compound 3 the middle estimate is 1.1-fold (0.05 log units) below the measured one; the range from low to high includes it.
By their numbers in this assay, from the lowest: compounds 1, 2 and 3 (each within the scatter of the next).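

Methyl in place of 4-bromophenyl on the carbonyl carbon gives, in this assay, no change at the digits printed from compound 2 to compound 3 (within the scatter) and so shows what the earlier pair could not: losing the ring altogether leaves the number where it stood. Methyl in place of pyridin-3-yl gives a 1.6-fold higher number from compound 1 to compound 3 (0.20 log units; within the scatter) and, with the earlier step, places all three groups on this carbonyl carbon within the scatter of one another. The data offer no measured explanation for this flat reading.

The compounds shown leave open whether a longer chain in place of methyl, or a ring carrying an amine or a carboxylic acid, would move the number beyond the scatter. They also leave open whether an amide in place of the ester link would read the same.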